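The compounds below may be only part of what the source reports. "The series", "measured", "known", "first", "only" and "open" are said of these compounds alone.

Measured so far:
compound 1 `Fc1cccc(F)c1Cc1cnc(Nc2ccc(Oc3cccnc3)c(Cl)c2)o1` with 16000 nM
compound 2 `Fc1cccc(F)c1Cc1cnc(Nc2ccc(Oc3cccnc3)cc2)o1` with 22000 nM

Both compounds were tested in an ADME assay on MT2 cells (Homo sapiens) for cytotoxicity, read by MTT assay; a lower number here means that less compound is tolerated, a higher number that more compound is tolerated. Compound 2 gives the highest of the two numbers, and its nearest neighbour is compound 1, which sits a 1.4-fold higher number from compound 1 to compound 2 (0.14 log units; within the scatter) away; that step is within the scatter, so the two compounds cannot be told apart in this assay.

Compound 3 `OCCc1ccc(Nc2ncc(Cc3c(F)cccc3F)o2)cc1` has not been measured. It differs from compound 2 in one place: 2-hydroxyethyl in place of (pyridin-3-yl)oxy on an aromatic carbon. Among the measured compounds shown here, no measured step touches this part of the shared core; the single step seen so far only swapped a chloro for a hydrogen elsewhere on the ring and changed nothing beyond the scatter. The numbers for compound 1 and compound 2 lie close together in this assay, so the expectation for compound 3 is a step of about a 1.1-fold higher number from compound 2 to compound 3 (0.06 log units; within the scatter) from compound 2, that is, no change beyond the scatter, with a wide range to allow for the untested group. Compound 3 is therefore estimated at 25000 nM in this assay, between 9000 nM and 60000 nM.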

Compound 3, half-maximal cytotoxic concentration: 35000 nM
For compound 3 the middle estimate is 1.4-fold (0.15 log units) below the measured one; the range from low to high includes it.
By their numbers in this assay, from the lowest: compounds 1, 2 and 3 (each within the scatter of the next, the first and the last beyond it).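

The earlier step only exchanged a chloro for a hydrogen, whereas this one replaces a whole substituent, on an aromatic carbon para to a large group. In this assay, swapping (pyridin-3-yl)oxy for 2-hydroxyethyl gives a 1.6-fold higher number from compound 2 to compound 3 (0.20 log units; within the scatter) and so does not separate the two compounds, even though an aromatic ring leaves, a shorter group with no ring enters, and a hydrogen-bond donor appears. At this position, then, a large change in structure need not produce a difference that this read-out can detect, and nothing measured here offers a reason for that outcome and it remains a plain observation from a single pair of compounds.

What the compounds shown leave open is whether this tolerance extends to other groups at the same position, such as an amine, a carboxylic acid or a longer chain, any of which might move the number beyond the scatter. From the compounds shown here alone, it is also open whether a chloro on the ring of compound 3 would leave the number as unchanged as it did alongside (pyridin-3-yl)oxy.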